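This account rests on a few compounds, and the source may have more. Where it says the series, first, only, none or still open, it means among the compounds named here.

Compound 1 `N#Cc1cc(F)cc(C(=O)Nc2ccccn2)c1`: in an in vitro functional assay on HEK293-A cells for antagonist activity at metabotropic glutamate receptor 5 (Rattus norvegicus), read by calcium flux (on this read-out higher numbers stand for weaker inhibition and lower numbers for stronger inhibition), compound 1 gives 3010 nM.
Compound 2 `N#Cc1cc(F)cc(C(=O)Nc2cccnc2)c1`: compound 2 gives > 30000 nM, which is a limit of the assay.
Compound 3 `N#Cc1cc(F)cc(C(=O)Nc2ccon2)c1`: compound 3 gives > 30000 nM, which is also a limit.

For the measured compounds named here, compound 1 holds the only actual number in this assay; the other two values sit at the limit of > 30000 nM in this assay, at which 2 of the 3 values shown sit. The steps of an at least 9.9-fold higher number from compound 1 to compound 2 (0.99 log units; beyond the scatter) and an at least 9.9-fold higher number from compound 1 to compound 3 (0.99 log units; beyond the scatter) each exchange the whole ring on the amide nitrogen for another. Compound 4 `Cc1ccnc(NC(=O)c2cc(F)cc(C#N)c2)c1` keeps the ring of compound 1 and differs from it only in methyl in place of hydrogen on an aromatic carbon. Going by the values given here, no measured step adds a group to a retained ring, so the two ring exchanges give no direct guide; they show only that this ring matters. The expected step is a 1.5-fold lower number from compound 1 to compound 4 (0.18 log units; within the scatter), within the scatter. Compound 4 is therefore estimated at 2000 nM, expected to fall between 500 nM and 8000 nM.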

Compound 4, half-maximal inhibitory concentration: > 10000 nM
Compound 4: no number, only a limit; the forecaster's own chance of this, stated with the estimate: 10%; at least 5.0-fold (0.69 log units) between middle value and limit.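

Whereas the earlier steps exchanged the whole ring, this one keeps the ring of compound 1 and puts a methyl on the aromatic carbon opposite the ring nitrogen, giving an at least 3.3-fold higher number from compound 1 to compound 4 (0.52 log units; beyond the scatter). So even this small addition to the retained ring weakens inhibition rather than leaving it unchanged. Compound 4 gives a limit rather than a number, so the full size of the loss cannot be read: the limit of > 10000 nM in this assay, at which 1 of the 4 values shown sits.

Going by these compounds, whether any group is accepted on this carbon remains open, since a chlorine or a methoxy group there could behave differently. Also open, on these data alone, is how a methyl would fare on the other ring carbons.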